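Chloro for fluoro on the amide-side ring

A few compounds are considered here, and "the series" means these few. Any claim that something is new, unique, unknown or untested is made for them only; others in the source may bear on it.

Compound 3, `O=C(Nc1ccc(F)cc1)c1ccc2cccc(O)c2n1`, shares its core with compound 1, `COc1ccc(NC(=O)c2ccc3cccc(O)c3n2)cc1`, and compound 2, `Cc1cccc(NC(=O)c2ccc3cccc(O)c3n2)c1`. In an ADME assay on THP-1 cells (Homo sapiens) for cytotoxicity, read by WST assay, with a stated time of 24 h (on this read-out higher numbers stand for weaker inhibition and lower numbers for stronger inhibition), compound 3 reports only a limit, > 30000 nM. Compound 1 likewise gives a limit in this assay, > 30000 nM. Compound 2 gives a limit as well, > 30000 nM. Thus (the limit of > 30000 nM in this assay, at which 3 of the 3 values shown sit). Within the data shown here, the step that the two limits leave unreadable from compound 1 to compound 3 and the step that the two limits leave unreadable from compound 2 to compound 3 are both unreadable in size; neither tells how far compound 3 lies past that limit, only that three values share it.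

Compound 4, `O=C(Nc1ccc(Cl)cc1)c1ccc2cccc(O)c2n1`, differs from compound 3 by chloro in place of fluoro on an aromatic carbon. Among the measured compounds shown here, no measured step exchanges these two halogens, and the two steps into compound 3 show nothing beyond limits. The step that the limit leaves unreadable from compound 3 to compound 4 is therefore expected to be none beyond the scatter, and this assay is expected most likely to return another limit. Compound 4 is estimated at 40000 nM, with a range from 20000 nM to 100000 nM.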

Compound 4, half-maximal inhibitory concentration: > 30000 nM
Compound 4 gave a limit, no number; the forecaster's own chance of this, stated with the estimate: 85%; the middle value lies beyond the limit too.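

In this assay compound 4 reports only a limit, as do compound 1, compound 2 and compound 3, so none of the steps joining compound 4 to them can be read in size. The compounds shown leave open how far any of them lies past that limit.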